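A few compounds are considered here, and "the series" means these few. Any claim that something is new, unique, unknown or untested is made for them only; others in the source may bear on it.

Series notes. Compound 1 `CC1(C)[C@H]2CC[C@]1(C)N(Cc1cn(-c3ccccc3F)nn1)C(=O)C2` serves as the reference point; in a functional assay on PANC-1 cells (Homo sapiens) for inhibition, read by MTT assay, with a stated time of 24 h (on this read-out lower numbers stand for stronger inhibition and higher numbers for weaker inhibition), compound 1 gives 150 nM. Two close analogues vary only the group on the aromatic nitrogen. Compound 2 `CC1(C)[C@H]2CC[C@]1(C)N(Cc1cn(-c3ccc(Br)cc3)nn1)C(=O)C2` gives 200 nM in this assay, and compound 3 `Cc1ccccc1-n1cc(CN2C(=O)C[C@@H]3CC[C@@]2(C)C3(C)C)nn1` gives 250 nM. Compound 1 holds the lowest of the three numbers, but all three sit within the scatter of one another, so no order among them can be claimed. The measured steps are a 1.3-fold higher number from compound 1 to compound 2 (0.12 log units; within the scatter), a 1.7-fold higher number from compound 1 to compound 3 (0.22 log units; within the scatter) and a 1.3-fold higher number from compound 2 to compound 3 (0.10 log units; within the scatter).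

The untested compound 4 `CC1(C)[C@H]2CC[C@]1(C)N(Cc1cn(-c3cccc(Br)c3)nn1)C(=O)C2` differs from compound 1 as follows: 3-bromophenyl in place of 2-fluorophenyl on an aromatic nitrogen. Among the compounds with values here, the steps that bear on this change are the two from compound 1, which likewise exchange the group on the aromatic nitrogen and both stay within the scatter; the exchange to compound 2, which also brings in bromine, is the closest precedent. For compound 4 no step beyond the scatter is expected in this assay, only a slight drift toward a higher number, a 1.3-fold higher number from compound 1 to compound 4 (0.12 log units; within the scatter). Compound 4 is therefore estimated at 200 nM, with an expected range from 100 nM to 400 nM.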

Compound 4, half-maximal inhibitory concentration: 90 nM
Beside the measured number, compound 4's estimate is 2.2-fold (0.35 log units) above it; measured number outside the range, below it.
By their numbers in this assay, from the lowest: compounds 4, 1, 2 and 3 (each within the scatter of the next, the first and the last beyond it).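

The group on the aromatic nitrogen now shows an effect beyond the scatter in this assay: exchanging 4-bromophenyl for 3-bromophenyl gives a 2.2-fold lower number from compound 2 to compound 4 (0.35 log units; beyond the scatter) and exchanging 2-methylphenyl for 3-bromophenyl gives a 2.8-fold lower number from compound 3 to compound 4 (0.44 log units; beyond the scatter). The exchange of 4-bromophenyl for 3-bromophenyl keeps the same halogen and changes only its place on the phenyl ring, so bromine alone does not set the number in this pair. The reference compound stays level with the new one, with a 1.7-fold lower number from compound 1 to compound 4 (0.22 log units; within the scatter), and no data here explain the gap between the two bromophenyl compounds.

Going by these compounds, it remains open whether the lower number belongs to bromine specifically or would also appear with 3-chlorophenyl or 3-methoxyphenyl. Also open, on these data alone, is how a phenyl ring carrying an amine or a carboxylic acid would behave on the same nitrogen.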